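Compound 3: hydrogen in place of bromo

This account rests on a few compounds, and the source may have more. Where it says the series, first, only, none or still open, it means among the compounds named here.

Two members of the series have been read in a functional assay on Caco-2 cells (Homo sapiens) for inhibition, read by sulforhodamine B assay, with a stated time of 48 h (on this read-out higher numbers stand for weaker inhibition and lower numbers for stronger inhibition), and neither gives a number. Compound 1 `COC(=O)[C@H]1C[C@@H](c2coc3ccccc3c2=O)N(c2ccccc2)O1` gives only a limit, > 60000 nM. Compound 2 `O=c1c([C@@H]2C[C@H](c3ccccc3)ON2c2ccccc2)coc2ccc(Br)cc12` also gives only a limit, > 60000 nM. The record so far comes down to the limit of > 60000 nM in this assay, at which 2 of the 2 values shown sit, so compound 2 cannot be ranked against compound 1.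

Compound 3 `O=c1c([C@@H]2C[C@H](c3ccccc3)ON2c2ccccc2)coc2ccccc12` is compound 2 with hydrogen in place of bromo on an aromatic carbon. That carbon belongs to a six-membered aromatic ring of carbon only, part of a fused system of two rings. Among the compounds with values here, no measured pair shows this change on its own, so the expectation has little support.

The expectation rests on compound 2, whose limit is > 60000 nM. No step beyond the usual scatter is expected in this assay, and a further limit is the likeliest report. The estimated change is a number no higher from compound 2 to compound 3 (the limit leaves the size open). The expected value for compound 3 is 60000 nM, within an estimated range of 25000 nM to 120000 nM.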

Compound 3, half-maximal inhibitory concentration: > 60000 nM
Compound 3 gave a limit, no number (the forecaster's own chance of this, stated with the estimate: 65%); the middle value sits exactly at the limit.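

No step can be read from compound 2 to compound 3 or from compound 1 to compound 3 in this assay, because each compound gives only a limit: the limit of > 60000 nM in this assay, at which 3 of the 3 values shown sit.

The compounds shown leave open whether bromo versus hydrogen, or phenyl versus methoxycarbonyl, changes inhibition, and whether any member of the series gives a number in this assay.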